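Swapping a fluorophenyl for a pyridone on a sulfonyl aryl

The compounds below may be only part of what the source reports. "The series", "measured", "known", "first", "only" and "open" are said of these compounds alone.

Measured so far:
- compound 1 `CCCCc1nc(=O)c(S(=O)(=O)c2ccc(-c3cccnc3)cc2)c(O)n1-c1c(OC)cccc1OC`: 202 nm/s
- compound 2 `CCCCc1[nH]c(=O)c(S(=O)(=O)c2ccc(-c3ccc(F)cc3)cc2)c(O)c1-c1c(OC)cccc1OC`: "not determined" (no result reported)

In an ADME assay for permeability, using PAMPA, at pH 5.5 (a lower number here means that the compound crosses the layer more slowly, a higher number that the compound crosses the layer faster), compound 1 gives 202 nm/s, while compound 2 gives "not determined" (no result reported), so compound 2 has no standing on the scale yet. Compound 3 `CCCCc1[nH]c(=O)c(S(=O)(=O)c2ccc(-n3ccccc3=O)cc2)c(O)c1-c1c(OC)cccc1OC` differs from compound 2 by a group of 7 heavy atoms (5 carbon, 1 nitrogen, 1 oxygen; one six-membered aromatic ring with 1 hetero atom) in place of a group of 7 heavy atoms (6 carbon, 1 fluorine; one six-membered aromatic ring of carbon only), on an aromatic carbon. Without a measured step to lean on, the expected change in this assay is a moderate drop, beyond the usual scatter but not large. Compound 3 is therefore estimated at 60 nm/s, within a range from 15 nm/s to 250 nm/s.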

Compound 3, apparent permeability: 177 nm/s
The estimate for compound 3 lay 3.0-fold (0.47 log units) below the measured number; the measured number falls inside the stated range.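

Among the compounds shown here, compound 2 has no single number in this assay so no step to compound 3 can be read. As far as these compounds go, what replacing the 4-fluorophenyl does to this read-out stays open, and no evidence bears on the result.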